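From nitro to carbamoyl in compound 3

This account rests on a few compounds, and the source may have more. Where it says the series, first, only, none or still open, it means among the compounds named here.

In an ADME assay for permeability, using PAMPA, at pH 7.4 (a higher number here means that the compound crosses the layer faster, a lower number that the compound crosses the layer more slowly), compound 1 (`CC(=O)c1ccc(NC(=O)Nc2cc(C)nc3ccccc23)cc1`) gives 473 10^-6 cm/s and compound 2 (`Cc1cc(NC(=O)Nc2cccc([N+](=O)[O-])c2)c2ccccc2n1`) gives 42 10^-6 cm/s as the lower of the two numbers, a gap well beyond the scatter. Compound 3 (`Cc1cc(NC(=O)Nc2cccc(C(N)=O)c2)c2ccccc2n1`) has carbamoyl in place of nitro on an aromatic carbon, meta to a large group (carbamoyl in place of nitro on an aromatic carbon). Going by the values given here, no measured pair shows this change, so the expectation rests on the two structures alone. In this assay a downward step beyond the scatter is expected (a 2.8-fold lower number from compound 2 to compound 3 (0.45 log units; beyond the scatter)). Compound 3 is estimated at 15 10^-6 cm/s (expected range 4 10^-6 cm/s to 45 10^-6 cm/s).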

Compound 3, apparent permeability: 2 10^-6 cm/s
Compound 3: middle estimate off by 7.5-fold (0.88 log units), on the high side; measured number outside the range, below it.
By their numbers in this assay, from the lowest: compound 3; then compound 2; then compound 1.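

In this assay the first single-place change gives a 21-fold lower number from compound 2 to compound 3 (1.32 log units; beyond the scatter) with carbamoyl in place of nitro on an aromatic carbon, meta to a large group. This position is therefore far from indifferent to the group it carries: each group has 3 heavy atoms, yet carbamoyl, with 1 hydrogen-bond donor against 0 for nitro, gives a large step. No measurement at hand accounts for this step.

The compounds shown leave open whether the drop is particular to carbamoyl. A nitrile or a methyl ester on the same aromatic carbon would test that.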